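Replacing a free amine hydrogen with a trifluoromethoxyphenyl group

A few compounds are considered here, and "the series" means these few. Any claim that something is new, unique, unknown or untested is made for them only; others in the source may bear on it.

Measured so far:
compound 1 `NC1=C(C(=O)c2ccccc2)C(c2ccc(Br)cc2)N(CCCn2ccnc2)C1=O`: "not active" (no number reported)
compound 2 `O=C(C1=C(Nc2ccccc2)C(=O)N(CCCn2ccnc2)C1c1ccc(Br)cc1)c1ccccc1`: 24100 nM
compound 3 `O=C(C1=C(Nc2ccc(F)cc2)C(=O)N(CCCn2ccnc2)C1c1ccc(Br)cc1)c1ccccc1`: 27400 nM

Of the compounds shown here, three sharing one core have been tested in a functional assay on A549 cells (Homo sapiens) for antiproliferative activity, read by MTT assay, with a stated time of 72 h; a higher number here means a weaker inhibitor, a lower number a stronger inhibitor. Compound 1 carries a free amino group on its core, and in this assay compound 1 was reported only as "not active" (no number reported), with no number attached, so it offers no fixed point on the scale. Compound 2 bears a phenylamino group in the same position and in this assay compound 2 gives 24100 nM. Compound 3 carries a fluoro-substituted phenylamino group and in this assay compound 3 gives 27400 nM. Among the compounds with values here, the single measured step, a 1.1-fold higher number from compound 2 to compound 3 (0.06 log units; within the scatter), is small.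

Compound 4 `O=C(C1=C(Nc2ccc(OC(F)(F)F)cc2)C(=O)N(CCCn2ccnc2)C1c1ccc(Br)cc1)c1ccccc1` differs from compound 1 by 4-(trifluoromethoxy)phenyl in place of hydrogen on an amine nitrogen. Within the data shown here, no measured step connects compound 1 to a number. The nearest guides are compounds 2 and 3, which both carry an arylamino group and sit close to one another, and the step of a 1.1-fold higher number from compound 2 to compound 3 (0.06 log units; within the scatter) shows that a substituent on that aryl ring changed little. Compound 4 is therefore expected in this assay to fall near those two, at an estimated 25000 nM, within a range of 8000 nM to 80000 nM.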

Compound 4, half-maximal inhibitory concentration: 20800 nM
For compound 4 the middle estimate is 1.2-fold (0.08 log units) above the measured one, and the stated range covers the measured number.
By their numbers in this assay, from the lowest: compounds 4, 2 and 3 (each within the scatter of the next).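

In this assay the step to 4-(trifluoromethoxy)phenyl on the amine nitrogen reads as a 1.2-fold lower number from compound 2 to compound 4 (0.06 log units; within the scatter) and as a 1.3-fold lower number from compound 3 to compound 4 (0.12 log units; within the scatter), so hydrogen, fluoro and trifluoromethoxy on this aryl ring now give three values with no separation beyond the scatter. The arylamino series thus holds for a substituent much larger than fluoro, and compound 4 gives a number where compound 1 stands as "not active" (no number reported). Nothing available explains this flat behaviour.

The compounds shown leave open whether a carboxylic acid or an amine on that aryl ring would move the number beyond the scatter. They also leave open whether a simple alkyl chain on the amine nitrogen, in place of the aryl group, would give a number at all.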